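The source may report more compounds than this note shows. Statements on the series, on what has been measured and on what is new or still open speak of the compounds shown alone.

Measured compounds:
Compound 1 `C=C[C@@](C)(/C=C/c1ccc(O)cc1)CC/C=C/C(=O)OCC`: > 36600 nM
Compound 2 `C=C[C@@](C)(/C=C/c1ccc(O)cc1)CC/C=C/C#N`: > 36600 nM
Compound 3 `COc1ccc(/C=C/[C@@](C)(/C=C/c2ccc(O)c(/C=C/C#N)c2)CCC=C(C)C)cc1`: 4540 nM

In a functional assay on SEM cells (Homo sapiens) for cytotoxicity, with a stated time of 72 h (a higher number here means that more compound is needed for the effect, a lower number that less compound is needed), compound 1 gives > 36600 nM, which is a limit of the assay and not a number. Compound 2 likewise gives > 36600 nM, again a limit. Compound 3 is the only one of the three with a number, giving 4540 nM. The change made from compound 2 to compound 1 is ethoxycarbonyl in place of cyano on a double-bonded chain carbon bound to a double-bonded chain carbon and it produced the step that the two limits leave unreadable from compound 2 to compound 1, which cannot be sized because the limit of > 36600 nM in this assay, at which 2 of the 3 values shown sit, holds both values. How the core of compound 3 differs from the core of compound 2 is not broken down here.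

Compound 4 `CCOC(=O)/C=C/c1cc(/C=C/[C@](C)(/C=C/c2ccc(OC)cc2)CCC=C(C)C)ccc1O` is not yet measured. It arises from compound 3 by the same change, (ethoxycarbonyl in place of cyano on a double-bonded chain carbon bound to a double-bonded chain carbon), at the same place. Since the earlier instance of this change gave no readable size, the expectation for compound 4 rests mainly on compound 3 and its value 4540 nM, and a step of about a 1.5-fold higher number from compound 3 to compound 4 (0.19 log units; within the scatter) is expected, within or near the usual scatter. Compound 4 is therefore estimated at 7000 nM, with a plausible range from 2500 nM to 25000 nM.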

Compound 4, half-maximal effective concentration: > 36600 nM
Compound 4 was reported as a limit (the forecaster's own chance of this, stated with the estimate: 15%); at least 5.2-fold (0.71 log units) between middle value and limit.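

On the core that carries the 2-cyanoethenyl group, the change to 2-(ethoxycarbonyl)ethenyl gives an at least 8.0-fold higher number from compound 3 to compound 4 (0.90 log units; beyond the scatter) in this assay, and this step lies beyond the scatter, with its full size unknown. In this assay compound 4 gives > 36600 nM, which is a limit and not a number. The earlier instance of the same change cannot be read, so this series offers only one step with a readable lower bound, and nothing shows that the change has a like effect on both cores, since both ends of the earlier step and the far end of this one sit at one limit: the limit of > 36600 nM in this assay, at which 3 of the 4 values shown sit.

The compounds shown leave open how other groups would read at this place, such as a carboxylic acid, a primary amide or a methyl ester. As far as these compounds go, they also leave open what the core of compound 3 gives with no 2-cyanoethenyl group at all, so what that group contributes to the value of compound 3, 4540 nM, stays unknown.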